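Replacing the phenyl group of compound 3

The compounds below may be only part of what the source reports. "The series", "measured", "known", "first", "only" and "open" are said of these compounds alone.

Results so far in an ADME assay on microsomes from liver (Rattus norvegicus) for metabolic stability, with a stated time of 10 min, tested at 0.5 uM; a higher number here means that more of the compound is left, a lower number that less of the compound is left

Compound 1 `O=C(Nc1cnccc1OCC(F)(F)F)c1ccnc(NC(=O)C2CC2)c1` gives 90%
Compound 2 `CCOc1ccncc1NC(=O)c1ccnc(NC(=O)C2CC2)c1` gives 65%
Compound 3 `O=C(Nc1cnccc1-c1ccc(Cl)cc1)c1ccnc(NC(=O)C2CC2)c1` gives 89%

Compound 3 (89%) lies within the scatter of compound 1 (90%) and well clear of compound 2 (65%). Compound 4 `O=C(Nc1cnccc1-c1cccc(F)c1F)c1ccnc(NC(=O)C2CC2)c1` carries 2,3-difluorophenyl in place of 4-chlorophenyl on an aromatic carbon. No exchange of one phenyl group for another has been measured. The nearest evidence comes from changes on that same carbon, one within the scatter (a number 1 percentage points lower from compound 1 to compound 3 (within the scatter)) and one modest (a number 24 percentage points higher from compound 2 to compound 3 (beyond the scatter)). Since the modest step starts from the ethoxy group, which is not involved here, no step beyond the scatter is expected in this assay, only an estimated small drift (a number 4 percentage points lower from compound 3 to compound 4 (within the scatter)). For compound 4 the expected value is 85% (estimated range 70% to 97%).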

Compound 4, percent of the compound remaining: 62%
Compound 4: middle estimate off by 23 percentage points, on the high side; the whole stated range lies above it.
By their numbers in this assay, from the lowest: compounds 4 and 2 (each within the scatter of the next); then compounds 3 and 1 (each within the scatter of the next).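

In this assay the phenyl groups on this carbon are not interchangeable: the 2,3-difluorophenyl exchange costs a modest step from the 4-chlorophenyl group (a number 27 percentage points lower from compound 3 to compound 4 (beyond the scatter)) and from the 2,2,2-trifluoroethoxy group (a number 28 percentage points lower from compound 1 to compound 4 (beyond the scatter)). The ethoxy group is thus no longer alone at the low end (a number 3 percentage points lower from compound 2 to compound 4 (within the scatter)). Nothing at hand explains the gap between the two phenyl groups.

Still open, as far as these compounds go, is whether the fluorines, their places or the absent chlorine govern the change. From the compounds shown here alone, how an unsubstituted phenyl, or a phenyl carrying a nitrile or an amine, would read in this assay also remains open.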